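The source may hold more compounds than are shown below. What is called first, only, known or untested is meant among the compounds shown, and "the series" means these compounds.

Measured so far in a functional assay on A549 cells (Homo sapiens) for antiproliferative activity, read by MTT assay, with a stated time of 24 h; a lower number here means a stronger inhibitor, a higher number a weaker inhibitor:
compound 1 `COc1ccc(-c2cc(C(=O)/C=C/c3ccccc3)nc3cc(-c4ccccc4)nn23)cc1OC` gives 18600 nM;
compound 2 `COc1ccc(C(=O)/C=C/c2cc(-c3ccc(OC)c(OC)c3)n3nc(-c4ccccc4)cc3n2)cc1` gives 11900 nM;
compound 3 `COc1ccc(-c2cc(/C=C/C(=O)c3ccccc3)nc3cc(-c4ccccc4)nn23)cc1OC` gives 10700 nM.

The highest number belongs to compound 1; however a 1.6-fold lower number from compound 1 to compound 2 (0.19 log units; within the scatter) and a 1.7-fold lower number from compound 1 to compound 3 (0.24 log units; within the scatter) both lie within the scatter, as does a 1.1-fold lower number from compound 2 to compound 3 (0.05 log units; within the scatter), so no order among the three can be read. Compound 4 `COc1ccc(-c2cc(C(=O)/C=C/c3cc(OC)c(OC)c(OC)c3)nc3cc(-c4ccccc4)nn23)cc1OC` differs from compound 1 by 3,4,5-trimethoxyphenyl in place of phenyl on a double-bonded chain carbon bound to a double-bonded chain carbon. Within the data shown here, none of the measured steps touches this position: two of them replace the (2-phenylethenyl)carbonyl group, the third puts hydrogen in place of methoxy on an aromatic carbon, and all stay within the scatter. No step beyond the scatter in this assay is therefore expected for a 1.6-fold lower number from compound 1 to compound 4 (0.19 log units; within the scatter). Compound 4 is estimated at 12000 nM, with a range of 4000 nM to 36000 nM.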

Compound 4, half-maximal inhibitory concentration: 15400 nM
Estimate against measurement, compound 4: 1.3-fold (0.11 log units) below; low and high end bracket the measured number.
By their numbers in this assay, from the lowest: compounds 3, 2, 4 and 1 (each within the scatter of the next).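

In this assay, 3,4,5-trimethoxyphenyl in place of phenyl on a double-bonded chain carbon bound to a double-bonded chain carbon gives a 1.2-fold lower number from compound 1 to compound 4 (0.08 log units; within the scatter). Among these compounds, this is the first change at this position, and this much larger group leaves the number within the scatter, so the position accepts the trimethoxy substitution without a readable step in either direction. No available evidence bears on this result.

Going by these compounds, whether an amine or a carboxylic acid in place of phenyl here would give a step beyond the scatter remains open. Also open, on these data alone, is whether 3,4,5-trimethoxyphenyl would act alike on the 2-benzoylethenyl side chain of compound 3.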